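The compounds below may be only part of what the source reports. "The series", "measured", "known", "first", "only" and "open" are said of these compounds alone.

Measured compounds:
compound 1 `c1ccc2c(-c3cn4ccnc4c(-c4ccc5ncn(C6CCCCC6)c5c4)n3)cccc2c1`: 9.45%
compound 2 `c1cn2cc(-c3ccc4c(c3)ncn4C3CCCCC3)nc(-c3ccc4ncn(C5CCCCC5)c4c3)c2n1`: 18.8%

In a functional assay on NCI-H226 cells (Homo sapiens) for inhibition, read by sulforhodamine B assay, with a stated time of 48 h, tested at 10 uM (a higher number here means more inhibition at the concentration tested (going by the name of the read-out), a lower number less inhibition), compound 1 gives 9.45% and compound 2 gives 18.8%. Compound 2 holds the higher of the two numbers, but its gap to compound 1 lies within the scatter, so the pair cannot be ordered. Compound 3 `c1ccc(Cn2cnc3ccc(-c4nc(-c5ccc6c(c5)ncn6C5CCCCC5)cn5ccnc45)cc32)cc1` is not yet measured; it differs from compound 2 by benzyl in place of cyclohexyl on an aromatic nitrogen. For the measured compounds named here, no measured pair shows what this change does, so in this assay a step of no more than the scatter is expected, in no set direction. Compound 3 is therefore estimated at 17%, with a range from 5% to 35%. The expected step is a number 1.8 percentage points lower from compound 2 to compound 3 (within the scatter).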

Compound 3, a percentage reported as inhibition, at one concentration (the size of the read-out at that concentration, not a potency): -63.1%
Beside the measured number, compound 3's estimate is 80.1 percentage points above it; measured number outside the range, below it.
By their numbers in this assay, from the lowest: compound 3; then compounds 1 and 2 (each within the scatter of the next).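

Benzyl in place of cyclohexyl on an aromatic nitrogen gives, in this assay, a number 81.9 percentage points lower from compound 2 to compound 3 (beyond the scatter). For the compounds shown here, this is the first measured change at this position, and it shows that the read-out responds strongly to the group there. Both groups have no hydrogen-bond donors or acceptors and no net charge, and no measurement available here accounts for the step.

From the compounds shown here alone, it remains open whether the aromatic ring or the carbon link of benzyl goes with the step. Phenyl, or a chain ending in an amine, on the same nitrogen would bear on this.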